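The source may report more compounds than this note shows. Statements on the series, on what has been measured and on what is new or still open speak of the compounds shown alone.

Measured so far:
compound 1 `Cc1ccc(/C=C/c2nc3cc(Br)ccc3[nH]c2=O)cc1`, 0.0222 ug/mL
compound 2 `Cc1nc2cc(Br)ccc2nc1Oc1ccc(N)cc1`, 0.00081 ug/mL

In a functional assay on MCF7 cells (Homo sapiens) for inhibition, read by sulforhodamine B assay, with a stated time of 72 h (a higher number here means a weaker inhibitor, a lower number a stronger inhibitor), compound 2 gives 0.00081 ug/mL, the lowest number of the two, with compound 1 at 0.0222 ug/mL, a gap beyond the scatter. Compound 3 `Cc1nc2cc(Br)ccc2nc1Oc1ccc(/N=C\c2ccc(Cl)cc2)cc1` differs from compound 2 by a group of 9 heavy atoms (7 carbon, 1 nitrogen, 1 chlorine; one six-membered aromatic ring of carbon only) in place of one nitrogen atom, on an aromatic carbon. Among the measured compounds shown here, no measured pair shows this kind of change, so the size of the step is open. Compound 3 is expected to give 0.003 ug/mL, between 0.0005 ug/mL and 0.02 ug/mL. That expectation means a step of a 3.7-fold higher number from compound 2 to compound 3 (0.57 log units; beyond the scatter), a modest move toward a higher number, within or just beyond the scatter.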

Compound 3, half-maximal inhibitory concentration: 0.00008 ug/mL
Estimate against measurement, compound 3: 38-fold (1.57 log units) above; measured number outside the range, below it.
By their numbers in this assay, from the lowest: compound 3; then compound 2; then compound 1.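

In this assay, the aromatic carbon para to a large group accepts much more than the amino group: the 9-heavy-atom group with its carbon-only aromatic ring and chlorine gives a 10-fold lower number from compound 2 to compound 3 (1.01 log units; beyond the scatter). For this pair, the hydrogen-bond donor of the amino group is not needed for a low number. Nothing available accounts for a step of this size.

Which part of the entering group carries the step remains open. It is also unknown how a fluorine in place of the chlorine, or an amide at this carbon, would compare.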